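Shifting a Hydroxyl Group on Compound 2

The compounds below may be only part of what the source reports. "The series", "measured", "known", "first", "only" and "open" are said of these compounds alone.

In an ADME assay on K562 cells (Homo sapiens) for cytotoxicity, with a stated time of 72 h (on this read-out higher numbers stand for weaker inhibition and lower numbers for stronger inhibition), compound 1 `Oc1cccc(CNc2ncnc3c2ncn3C2CCCCO2)c1` gives 81000 nM as its reading. Compound 2 `Oc1ccccc1CNc1ncnc2c1ncn2C1CCCO1` reads > 100000 nM and that is a limit of the assay, not a number. Compound 3 `Oc1cccc(CNc2ncnc3c2ncn3C2CCCO2)c1` has 3-hydroxyphenyl in place of 2-hydroxyphenyl on a saturated chain carbon bound to a nitrogen on an aromatic ring. Compound 1 also carries 3-hydroxyphenyl at 81000 nM and so in this assay only a small move toward stronger inhibition is expected, possibly none beyond the scatter. The estimate means an at least 1.2-fold lower number from compound 2 to compound 3 (0.09 log units; that floor lies within the scatter) as the expected step. For compound 3 the estimated value is 80000 nM with an expected range from 35000 nM to 150000 nM in this read-out.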

Compound 3, half-maximal inhibitory concentration: > 100000 nM
Compound 3 ended at the assay's limit; the forecaster's own chance of this, stated with the estimate: 45%; middle value at least 1.2-fold (0.09 log units) away from the limit.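

Moving from 2-hydroxyphenyl to 3-hydroxyphenyl gives no readable result in this assay: the readings for compound 2 and compound 3 are both limits, not numbers, so the step between them cannot be read. Replacing oxan-2-yl with oxolan-2-yl on an aromatic nitrogen, with 3-hydroxyphenyl kept, gives an at least 1.2-fold higher number from compound 1 to compound 3 (0.09 log units; that floor lies within the scatter), so that change shows no clear effect. The limit also hides most of this small series: the limit of > 100000 nM in this assay, at which 2 of the 3 values shown sit.

Going by these compounds, whether the two hydroxyphenyl groups truly differ stays open. So does how an aminophenyl group or a carboxylic acid would read in the same place.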